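Chloro in Place of Iodo on a Weakly Cytotoxic Scaffold

The source may hold more compounds than are shown below. What is called first, only, known or untested is meant among the compounds shown, and "the series" means these compounds.

Of the compounds shown here, two built on quite different frameworks have been tested for their ability to kill prostate-derived tumour cells. Compound 1 `C#CC1=CC[C@]2(CC1)C(=C)CC[C@H]2C(C)C` is a terpene-like hydrocarbon, and in a functional assay on DU-145 cells (Homo sapiens) for cytotoxicity, read by MTT assay, with a stated time of 48 h (on this read-out higher numbers stand for weaker inhibition and lower numbers for stronger inhibition), compound 1 gives 121000 nM. Compound 2 `C=C1CCC[C@]2(C)CCC(c3cn(-c4ccc(I)cc4)nn3)=CC[C@@]12C` carries a 4-iodophenyl group attached through a five-membered nitrogen ring to a larger bicyclic core, and in this assay compound 2 gives 145000 nM. The two numbers lie within the usual scatter of one another, so nothing distinguishes the two compounds on this read-out: both are weak.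

Compound 3 `C=C1CCC[C@]2(C)CCC(c3cn(-c4ccc(Cl)cc4)nn3)=CC[C@@]12C` differs from compound 2 in one place: chloro in place of iodo on an aromatic carbon. Everything else in the molecule is kept. Within the data shown here, the only measured comparison, between compound 1 and compound 2, involves unrelated frameworks. It offers no guide to how a halogen swap on the aryl ring might matter here.

For compound 3 the expectation is a step of no more than the scatter, a 1.1-fold higher number from compound 2 to compound 3 (0.04 log units; within the scatter), with the estimate in this assay being 160000 nM, plausibly anywhere from 70000 nM to 350000 nM.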

Compound 3, half-maximal inhibitory concentration: 26000 nM
The estimate for compound 3 lay 6.2-fold (0.79 log units) above the measured number, and the stated range ends above it.
By their numbers in this assay, from the lowest: compound 3; then compounds 1 and 2 (each within the scatter of the next).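

In this assay the change from 4-iodophenyl to 4-chlorophenyl brings a 5.6-fold lower number from compound 2 to compound 3 (0.75 log units; beyond the scatter) and so gives the first difference in this small set that lies beyond the usual scatter. The position on the aromatic ring, para to a large group, is therefore not silent on this read-out: the identity of the halogen there changes the number, even though the shared core stays the same and the swap exchanges one heavy atom for one heavy atom, with no change in ring count, hydrogen-bond donors, hydrogen-bond acceptors or net charge. No measurement at hand explains why this swap changes the number.

With only iodo and chloro shown at this position, two points cannot show a trend, so it remains open how a fluoro, a bromo, a methoxy or an amine would read there, or a plain hydrogen with no group at all. On these data alone, it also remains open whether the same swap would have a comparable effect in other cell lines or on a different core.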